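Iodo Substitution Tested at the Hemolysis Limit

This account rests on a few compounds, and the source may have more. Where it says the series, first, only, none or still open, it means among the compounds named here.

Compound 1 `CC(=NNC(=S)Nc1ccccc1F)c1ccccn1`: in an ADME assay on cells (Erythrocyte, Homo sapiens), read by hemolysis, with a stated time of 1 h (a lower number here means a stronger inhibitor, a higher number a weaker inhibitor), compound 1 gives > 10000 nM, a limit of the assay and not a number.
Compound 2 `CC(=NNC(=S)Nc1ccccc1)c1ccccn1`: in this assay compound 2 gives > 10000 nM, again a limit of the assay.

Among the compounds with values here, compound 2 therefore stands at the limit, not at a measured number; the only evidence on the measured pair is the limit of > 10000 nM in this assay, at which 2 of the 2 values shown sit. Within the data shown here, the one measured step, a step that the two limits leave unreadable from compound 1 to compound 2, is unreadable in size because both of its ends are limits. Compound 3 `CC(=NNC(=S)Nc1ccc(I)cc1)c1ccccn1` differs from compound 2 by iodo in place of hydrogen on an aromatic carbon. Among the measured compounds shown here, no measured step speaks readably to this change, so no direction can be drawn from the data. Compound 3 is expected to sit near the limit as well, with a step that the limit leaves unreadable from compound 2 to compound 3 expected from compound 2. Compound 3 is estimated at 15000 nM, with a range from 5000 nM to 50000 nM.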

Compound 3, half-maximal inhibitory concentration: > 10000 nM
Compound 3: only a limit was reported (the forecaster's own chance of this, stated with the estimate: 80%); the middle value does not contradict the limit.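

No step can be read between compound 2 and compound 3 in this assay, because both ends are limits: the limit of > 10000 nM in this assay, at which 3 of the 3 values shown sit.

The compounds shown leave open where any of them truly stands in this assay, and whether iodo in place of hydrogen on an aromatic carbon shifts the read-out at all.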